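Anilide Variation on a Coumarin-Type Amide Series

The source may report more compounds than this note shows. Statements on the series, on what has been measured and on what is new or still open speak of the compounds shown alone.

The measured compounds and their values in an in vitro assay on BTI-TN-5B1-4 cells for inhibition of Amine oxidase [flavin-containing] B (Homo sapiens), read by fluorescence (a lower number here means a stronger inhibitor, a higher number a weaker inhibitor), are:

Compound 1 `CC(C)CNC(=O)c1cc2ccccc2oc1=O`: 3270 nM
Compound 2 `Cc1ccc(NC(=O)c2cc3ccccc3oc2=O)cc1`: 710 nM
Compound 3 `COc1ccc(NC(=O)c2cc3ccccc3oc2=O)cc1`: 820 nM

Compound 3 stands second highest of the three numbers in this assay. Its nearest neighbour is compound 2, separated by a 1.2-fold higher number from compound 2 to compound 3 (0.06 log units; within the scatter), a gap that lies within the scatter. Its furthest neighbour is compound 1, and the step of a 4.6-fold lower number from compound 1 to compound 2 (0.66 log units; beyond the scatter) shows how far the alkyl amide sits from the two anilides.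

Compound 4 `O=C(Nc1ccc(O)cc1)c1cc2ccccc2oc1=O` differs from compound 3 by hydrogen in place of methyl on an oxygen on an aromatic ring. Going by the values given here, no measured step covers this exact change. The step that bears on it most closely is a 1.2-fold higher number from compound 2 to compound 3 (0.06 log units; within the scatter), in which a different exchange at the same part of the molecule left the number within the scatter. The larger step of a 4.6-fold lower number from compound 1 to compound 2 (0.66 log units; beyond the scatter) concerns a different position and offers no guidance here.

On that basis the step from compound 3 to compound 4 is expected to be small, a 1.2-fold higher number from compound 3 to compound 4 (0.09 log units; within the scatter), with no clear direction beyond the scatter. For compound 4 the estimated value in this assay is 1000 nM, within a range of 400 nM to 2500 nM.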

Compound 4, half-maximal inhibitory concentration: 800 nM
Compound 4: the middle estimate sits 1.3-fold (0.10 log units) above what was measured; measured number inside the range.
By their numbers in this assay, from the lowest: compounds 2, 4 and 3 (each within the scatter of the next); then compound 1.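

In this assay, taking the methyl off the oxygen on the aromatic ring leaves the number where it was (a 1.0-fold lower number from compound 3 to compound 4 (0.01 log units; within the scatter)), so the methoxy to hydroxy exchange shows no change beyond the scatter. Together with the step from the methyl anilide (a 1.1-fold higher number from compound 2 to compound 4 (0.05 log units; within the scatter)), this means that methyl, methoxy and hydroxy all read alike at this place, and the 4-hydroxyphenyl amide stays clear of the isobutyl amide (a 4.1-fold lower number from compound 1 to compound 4 (0.61 log units; beyond the scatter)). Nothing measured here explains why these three groups read alike.

The compounds shown leave open whether this flat reading extends to an amine, a carboxylic acid or a longer alkoxy chain at the same place. They also leave open how an unsubstituted phenyl on the amide nitrogen would compare with these anilides.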